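Working notes: from compound 2 to compound 3

This account rests on a few compounds, and the source may have more. Where it says the series, first, only, none or still open, it means among the compounds named here.

In an ADME assay on a cell-free system (plasma, Rattus norvegicus) for metabolic stability, read by LC-MS, with a stated time of 60 min, tested at 100 uM (on this read-out lower numbers stand for a less stable compound and higher numbers for a more stable compound), compound 1 (`Cc1c(OCCCCOCOc2ccc(C(=O)O)cc2)ccc(C(=O)CC2CCCC2)c1O`) gives 100% and compound 2 (`COc1ccc(C(=O)O)cc1OCCCCOc1ccc(C(=O)CC2CCCC2)c(O)c1C`) gives 103%. Going by the values given here, these are the only two numbers available for the series, and they lie within the scatter of each other, so compound 2 cannot be separated from compound 1 on this read-out. Compound 3 (`Cc1cc(C(=O)O)ccc1OCCCCOc1ccc(C(=O)CC2CCCC2)c(O)c1C`) has not yet been measured. It carries 4-carboxy-2-methylphenyl in place of the 5-carboxy-2-methoxyphenyl of compound 2, on an oxygen on a saturated carbon: 4-carboxy-2-methylphenyl in place of 5-carboxy-2-methoxyphenyl on an oxygen on a saturated carbon. Among the compounds with values here, one measured step bears on this change, since it was made at the same kind of place: a number 3 percentage points higher from compound 1 to compound 2 (within the scatter). That step stayed within the scatter, although a single step is thin evidence. The expected step is a number 3 percentage points lower from compound 2 to compound 3 (within the scatter), which means no change beyond the scatter is expected. For compound 3 the estimated value is 100%, with an expected range from 88% to 110%.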

Compound 3, percent of the compound remaining: 99%
The estimate for compound 3 lay 1 percentage points above the measured number; the range from low to high includes it.
By their numbers in this assay, from the lowest: compounds 3, 1 and 2 (each within the scatter of the next).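

In this assay, 4-carboxy-2-methylphenyl in place of 5-carboxy-2-methoxyphenyl gives a number 4 percentage points lower from compound 2 to compound 3 (within the scatter), and the same group in place of (4-carboxyphenoxy)methyl gives a number 1 percentage points lower from compound 1 to compound 3 (within the scatter), so this place, on an oxygen on a saturated carbon, now has three different carboxy-bearing groups that cannot be separated on this read-out. The entering group has fewer heavy atoms and fewer hydrogen-bond acceptors than 5-carboxy-2-methoxyphenyl, and even so the read-out shows no step beyond the scatter. Nothing available bears on why these compounds cannot be told apart.

An amine in place of the carboxylic acid on this aromatic ring remains untested in the compounds shown. Going by these compounds, whether any group at this place can move the read-out beyond the scatter also stays open.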